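Swapping the pentyloxy group for benzylamino on the shared core

A few compounds are considered here, and "the series" means these few. Any claim that something is new, unique, unknown or untested is made for them only; others in the source may bear on it.

In a functional assay on A549 cells (Homo sapiens) for antiproliferative activity, read by MTT assay, with a stated time of 72 h (on this read-out higher numbers stand for weaker inhibition and lower numbers for stronger inhibition), the starting point is compound 1 `CCCCCOC1=C(C(=O)c2ccccc2)C(c2ccc(Br)cc2)N(CCCn2ccnc2)C1=O`, which gives 7290 nM and stands lowest of the three compounds measured. Its two measured neighbours differ from it only at the same ring position: compound 2 `CCOc1ccc(NC2=C(C(=O)c3ccccc3)C(c3ccc(Br)cc3)N(CCCn3ccnc3)C2=O)cc1` gives 20200 nM, and compound 3 `O=C(C1=C(Nc2cccc(Br)c2)C(=O)N(CCCn2ccnc2)C1c1ccc(Br)cc1)c1ccccc1` gives 15800 nM. The step of a 2.8-fold higher number from compound 1 to compound 2 (0.44 log units; beyond the scatter) and the step of a 2.2-fold higher number from compound 1 to compound 3 (0.34 log units; beyond the scatter) both go the same way, each a modest weakening, while the step of a 1.3-fold lower number from compound 2 to compound 3 (0.11 log units; within the scatter) lies within the scatter, so the two anilino variants cannot be told apart.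

Compound 4 `O=C(C1=C(NCc2ccccc2)C(=O)N(CCCn2ccnc2)C1c1ccc(Br)cc1)c1ccccc1` takes the same route once more: benzylamino in place of pentyloxy on a double-bonded ring carbon. Within the data shown here, both measured steps from compound 1 concern an amino group entering at this double-bonded ring carbon, and both point to a somewhat higher number; the benzylamino group differs from either of them by carrying its aromatic ring on a methylene rather than directly on the nitrogen, for which no measured pair exists. Compound 4 is therefore expected to land modestly above compound 1, with an estimated step of a 1.9-fold higher number from compound 1 to compound 4 (0.28 log units; within the scatter). The estimate for compound 4 in this assay is 14000 nM, within a range from 5500 nM to 36000 nM.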

Compound 4, half-maximal inhibitory concentration: 52800 nM
Estimate against measurement, compound 4: 3.8-fold (0.58 log units) below, outside the stated range (above it).
By their numbers in this assay, from the lowest: compound 1; then compounds 3 and 2 (each within the scatter of the next); then compound 4.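

In this assay, the result shows that what the amine nitrogen carries at this double-bonded ring carbon matters, and not only the entry of an amino group: putting benzyl in place of an aryl group on that nitrogen gives a 3.3-fold higher number from compound 3 to compound 4 (0.52 log units; beyond the scatter) and a 2.6-fold higher number from compound 2 to compound 4 (0.42 log units; beyond the scatter) even though the two anilino variants could not be told apart. The full change from pentyloxy to benzylamino gives a 7.2-fold higher number from compound 1 to compound 4 (0.86 log units; beyond the scatter) and is the largest step from compound 1 among the compounds shown, so all three amino compounds stand above compound 1 and none goes against that order. Nothing available gives a reason for the added rise with benzylamino.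

The compounds shown do not separate the effect of the linking nitrogen from that of the aromatic ring, a question that a benzyloxy group or a pentylamino group at the same ring carbon could address. On these data alone, it also remains open whether the rise tracks the methylene of the benzyl group, which a phenethylamino group or an unsubstituted anilino group would help to test.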